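A few compounds are considered here, and "the series" means these few. Any claim that something is new, unique, unknown or untested is made for them only; others in the source may bear on it.

Compound 1 `COc1c(F)cccc1N1C(=O)CSC1c1cccc(C(=O)NCCCCc2ccccc2)c1` gives 9% in a functional assay on HOS cells (Homo sapiens) for inhibition, read by CCK-8 assay, with a stated time of 72 h, tested at 1 uM; on this read-out lower numbers stand for less inhibition and higher numbers for more inhibition at the one concentration tested (going by the name of the read-out). Compound 2 `O=C(NCCCCc1ccccc1)c1cccc(C2SCC(=O)N2c2ccccc2)c1` gives 55%. Compound 3 `COc1ccc(F)cc1N1C(=O)CSC1c1cccc(C(=O)NCCCCc2ccccc2)c1` gives 46%.

Compound 3 stands second highest of the three numbers. Its nearest neighbour is compound 2: a number 9 percentage points lower from compound 2 to compound 3 (within the scatter). Furthest away is compound 1: a number 37 percentage points higher from compound 1 to compound 3 (beyond the scatter). Compound 4 `COc1ccc(N2C(=O)CSC2c2cccc(C(=O)NCCCCc3ccccc3)c2)c(OC)c1` differs from compound 3 in one place: 2,4-dimethoxyphenyl in place of 5-fluoro-2-methoxyphenyl on an amide-type nitrogen in a ring. Among the compounds with values here, two measured steps concern the group on an amide-type nitrogen in a ring. One was large, a number 37 percentage points higher from compound 1 to compound 3 (beyond the scatter), while the other stayed within the scatter, a number 9 percentage points lower from compound 2 to compound 3 (within the scatter), so such exchanges have moved the number both greatly and hardly at all. A modest downward step is expected for compound 4, a number 8 percentage points lower from compound 3 to compound 4 (within the scatter). Compound 4 is estimated at 38%, between 12% and 60%.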

Compound 4, a percentage reported as inhibition, at one concentration (the size of the read-out at that concentration, not a potency): 82%
Estimate against measurement, compound 4: 44 percentage points below; measured number outside the range, above it.
By their numbers in this assay, from the lowest: compound 1; then compounds 3 and 2 (each within the scatter of the next); then compound 4.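

In this assay, a group on the amide-type nitrogen in a ring can lift the number well past that of plain phenyl: with 2,4-dimethoxyphenyl there is a number 27 percentage points higher from compound 2 to compound 4 (beyond the scatter), whereas the earlier exchange away from phenyl stayed within the scatter. The same group gives a number 36 percentage points higher from compound 3 to compound 4 (beyond the scatter) and a number 73 percentage points higher from compound 1 to compound 4 (beyond the scatter), so compound 4 stands highest of the four. No measured evidence bears on why this exchange has such an effect.

The compounds shown leave open whether phenyl carrying a single methoxy group would keep this rise. They also leave open how a dimethylamino group or a longer ether chain would fare at this place.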